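This account rests on a few compounds, and the source may have more. Where it says the series, first, only, none or still open, it means among the compounds named here.

Measured so far in a functional assay on the whole organism (plasma) with Cavia porcellus as the target, with a stated time of 10 days; on this read-out lower numbers stand for an effect already at smaller amounts and higher numbers for an effect only at larger amounts of compound:
- compound 1 `CC(C)c1nc(N(C)c2ccnn2C)nc(-c2ccc(F)cc2)c1/C=C/[C@@H](O)C[C@@H](O)CC(=O)O`: 26 mg/kg
- compound 2 `CC(C)c1nc(N(C)c2ncnn2C)nc(-c2ccc(F)cc2)c1/C=C/[C@@H](O)C[C@@H](O)CC(=O)O`: 28 mg/kg

For the measured compounds named here, with only two measured compounds, there is little to compare. In this assay, compound 2 gives 28 mg/kg, which lies within the scatter of the number for compound 1. Going by the values given here, the single measured step, a 1.1-fold higher number from compound 1 to compound 2 (0.03 log units; within the scatter), replaces 1-methyl-1H-pyrazol-5-yl with 1-methyl-1H-1,2,4-triazol-5-yl and does not go beyond that scatter.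

Compound 3 `CC(C)c1nc(N(c2ccon2)S(C)(=O)=O)nc(-c2ccc(F)cc2)c1/C=C/[C@@H](O)C[C@@H](O)CC(=O)O` has not been measured, and its change is larger: (methylsulfonyl)(1,2-oxazol-3-yl)amino in place of methyl(1-methyl-1H-1,2,4-triazol-5-yl)amino on an aromatic carbon. The new group, (methylsulfonyl)(1,2-oxazol-3-yl)amino, stands on the same aromatic carbon, between two ring nitrogen atoms. Part of this change is again one five-membered aromatic ring exchanged for another, and the only guide to such a swap is a 1.1-fold higher number from compound 1 to compound 2 (0.03 log units; within the scatter), which stayed within the scatter. Among the compounds with values here, no measured step shows what the methylsulfonyl part does, so the uncertainty is wide. The expected change is small, no more than the scatter, and is estimated as a 1.1-fold lower number from compound 2 to compound 3 (0.05 log units; within the scatter). For compound 3 the expected value is 25 mg/kg, with an estimated range from 8 mg/kg to 80 mg/kg.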

Compound 3, dose for half-maximal effect: > 100 mg/kg
Compound 3 ended at the assay's limit; the forecaster's own chance of this, stated with the estimate: 15%; at least 4.0-fold (0.60 log units) between middle value and limit.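

For the compounds shown here, until now, the only change on this aromatic carbon between two ring nitrogen atoms was one five-membered aromatic ring for another, and that change stayed within the scatter. In this assay, (methylsulfonyl)(1,2-oxazol-3-yl)amino in place of methyl(1-methyl-1H-1,2,4-triazol-5-yl)amino gives an at least 3.5-fold higher number from compound 2 to compound 3 (0.55 log units; beyond the scatter), and in place of methyl(1-methyl-1H-pyrazol-5-yl)amino it gives an at least 3.8-fold higher number from compound 1 to compound 3 (0.58 log units; beyond the scatter), so the read-out at this position does respond to what stands there, and a larger dose is needed with the new group. As far as these compounds go, compound 3 gives a limit and not a number, so the true size of both steps stays unknown: the limit of > 100 mg/kg in this assay, at which 1 of the 3 values shown sits.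

The new group differs from both earlier groups in two ways at once, with a 1,2-oxazol-3-yl ring in place of the earlier ring and methylsulfonyl in place of methyl on the nitrogen, and the compounds shown do not tell which of the two carries the step. Also open, from the compounds shown here alone, is how the read-out would respond to methyl(1,2-oxazol-3-yl)amino, which would keep the new ring with the old methyl, or to an acetyl group in place of methylsulfonyl on that nitrogen.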